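Boc capping of the amide nitrogen: cytotoxicity notes

The source may report more compounds than this note shows. Statements on the series, on what has been measured and on what is new or still open speak of the compounds shown alone.

Compound 1 `CC(C)(C)OC(=O)N(Cc1ccco1)C(=O)c1ccc(CN2C(=O)c3ccccc3C2=O)cc1` and compound 2 `O=C(NCc1ccco1)c1ccc(CN2C(=O)c3ccccc3C2=O)cc1` share one core; compound 3 `CNC(=O)c1ccc(CN2C(=O)c3ccccc3S2(=O)=O)cc1` and compound 4 `CN(C(=O)OC(C)(C)C)C(=O)c1ccc(CN2C(=O)c3ccccc3S2(=O)=O)cc1` share another, and the difference between the two cores is not broken down here. In an ADME assay on RAW264.7 cells (Mus musculus) for cytotoxicity, read by WST assay (on this read-out lower numbers stand for higher toxicity in this test and higher numbers for lower toxicity in this test), compound 1 gives > 100000 nM, a limit of the assay. In this assay compound 2 gives > 100000 nM, likewise a limit. In this assay compound 3 gives > 100000 nM, again a limit. From compound 2 to compound 1 the change is tert-butoxycarbonyl in place of hydrogen on an amide-type nitrogen and the step is a step that the two limits leave unreadable from compound 2 to compound 1, both ends sitting at the limit of > 100000 nM in this assay, at which 3 of the 3 values shown sit. The same change, (tert-butoxycarbonyl in place of hydrogen on an amide-type nitrogen), turns compound 3 into compound 4. The step from compound 3 to compound 4 is expected to be a step that the limit leaves unreadable from compound 3 to compound 4, since the measured pair rests at the limit of > 100000 nM in this assay, at which 3 of the 3 values shown sit. Compound 4 is thus estimated at 200000 nM in this assay.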

Compound 4, concentration lethal to 50% of the cells: > 100000 nM
Compound 4: no number, only a limit; the forecaster's own chance of this, stated with the estimate: 85%; the middle value is on the limit's open side.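

No step can be read between compound 3 and compound 4, since both values are limits: the limit of > 100000 nM in this assay, at which 4 of the 4 values shown sit. The compounds shown leave open whether tert-butoxycarbonyl in place of hydrogen on an amide-type nitrogen changes the read-out at all in this assay.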